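A few compounds are considered here, and "the series" means these few. Any claim that something is new, unique, unknown or untested is made for them only; others in the source may bear on it.

Of the compounds shown here, three have so far been tested in an ADME assay on microsomes from liver (Homo sapiens) for metabolic stability, read by LC-MS, with a stated time of 10 min, tested at 0.5 uM; on this read-out higher numbers stand for a more stable compound and lower numbers for a less stable compound. Compound 1 `c1ccc2c(c1)CN[C@@H](CN(CC[C@H]1CCCNC1)[C@H]1CCCc3cccnc31)C2` gives 93% in this assay, compound 3 `c1ccc2c(c1)CN[C@@H](CN(CCN1CCNCC1)[C@H]1CCCc3cccnc31)C2` gives 96%, and compound 2 `c1cnc(CN(CCCN2CCNCC2)[C@H]2CCCc3cccnc32)nc1` gives 100%. Compound 2 stands highest of the three numbers, yet compound 3 and compound 1 both sit within the usual scatter of it, so no real order can be read from these three.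

Compound 4 `c1cnc2c(c1)CN[C@@H](CN(CCCN1CCNCC1)[C@H]1CCCc3cccnc31)C2` has not yet been measured in this assay. Compared with compound 2 it differs as follows: a group of 10 heavy atoms (8 carbon, 2 nitrogen; one six-membered non-aromatic ring with 1 hetero atom, one six-membered aromatic ring with 1 hetero atom) in place of a group of 6 heavy atoms (4 carbon, 2 nitrogen; one six-membered aromatic ring with 2 hetero atoms), on a saturated chain carbon bound to an amine nitrogen. Going by the values given here, the only measured step that changes a single group, a number 3 percentage points higher from compound 1 to compound 3 (within the scatter), concerns a different part of the molecule, the far end of a chain hanging from the amine nitrogen, and it stayed within the scatter. Among the compounds with values here, no measured pair swaps the group that changes here. Within the data shown here, what the data do show is that all three measured compounds keep nearly all of the material after the incubation, and that compound 3, which carries a group resembling the one entering in compound 4, and compound 2, which carries the one that leaves, sit close together. The step of a number 5 percentage points lower from compound 2 to compound 4 (within the scatter) is therefore expected to stay within the scatter. Compound 4 is estimated at 95%, with a range from 85% to 100%.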

Compound 4, percent of the compound remaining: 79%
Compound 4: the middle estimate sits 16 percentage points above what was measured, and the stated range ends above it.
By their numbers in this assay, from the lowest: compound 4; then compounds 1, 3 and 2 (each within the scatter of the next).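

In this assay, putting the group of 10 heavy atoms in place of pyrimidin-2-yl gives a number 21 percentage points lower from compound 2 to compound 4 (beyond the scatter), and this is the first step shown that lies beyond the scatter. Going by these compounds alone, the place on a saturated chain carbon bound to an amine nitrogen is therefore one where this read-out can respond to a change of group, whereas the only earlier step, a number 3 percentage points higher from compound 1 to compound 3 (within the scatter), concerned another part of the molecule and stayed within the scatter. No measurement shown here gives a reason for this drop.

The entering group differs from pyrimidin-2-yl in several ways at once: it is larger, and it adds a six-membered non-aromatic ring, a hydrogen-bond donor and a defined stereocentre, so the step cannot be pinned on any one of these. Still open, as far as these compounds go, is whether a single aromatic ring such as phenyl or pyridin-2-yl at this place would keep the number close to that of compound 2, which would show how much of the step depends on the added non-aromatic ring.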